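A Thiazole Ring Replaces Pyridine on the Sulfonyl Sulfur

A few compounds are considered here, and "the series" means these few. Any claim that something is new, unique, unknown or untested is made for them only; others in the source may bear on it.

Compound 1 `CC1CCN(C2CCN(S(=O)(=O)c3cccnc3)CC2)CC1` is a sulfonamide built around a pair of linked saturated rings, with a pyridin-3-yl group on the sulfonyl sulfur. In a functional assay on DLD-1 cells (Homo sapiens) for antiproliferative activity, read by CellTiter-Glo, with a stated time of 72 h (on this read-out higher numbers stand for weaker inhibition and lower numbers for stronger inhibition), compound 1 gives 2400 nM. Among the results shown, this is the only true number. Compound 2 `COc1cc(C)ccc1S(=O)(=O)N1CCC(N2CCC(C)CC2)CC1` carries a different aromatic group on the sulfonyl sulfur. In this assay compound 2 gives > 5000 nM, which is a limit of the assay and not a number. Compound 1 therefore stands as the single measured point, while the other value rests at the limit of > 5000 nM in this assay, at which 1 of the 2 values shown sits.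

Compound 3 `Cc1nc(Cl)sc1S(=O)(=O)N1CCC(N2CCC(C)CC2)CC1` has not been tested. It differs from compound 1 by 2-chloro-4-methyl-1,3-thiazol-5-yl in place of pyridin-3-yl on a sulfonyl sulfur. For the measured compounds named here, no measured pair shows what such a change does here, so the expected step is small, with no clear direction and nothing beyond the usual scatter. The step of a 1.2-fold lower number from compound 1 to compound 3 (0.08 log units; within the scatter) is the one expected. Compound 3 is estimated at 2000 nM in this assay, with a range from 600 nM to 6000 nM.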

Compound 3, half-maximal inhibitory concentration: 1.6 nM
Beside the measured number, compound 3's estimate is 1300-fold (3.10 log units) above it; the whole stated range lies above it.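

The group on the sulfonyl sulfur turns out to have a very strong effect on the result in this assay: 2-chloro-4-methyl-1,3-thiazol-5-yl in place of pyridin-3-yl gives a 1500-fold lower number from compound 1 to compound 3 (3.18 log units; beyond the scatter), and this single change moves the compound from a weak inhibitor of cell growth to a very strong one. Compound 2, which carries another aromatic group at this position, gives a limit of the assay and not a number, so that its distance from compound 3 cannot be stated as a step: the limit of > 5000 nM in this assay, at which 1 of the 3 values shown sits. No measurement shown explains why this change has such a large effect, so the result records what happens at this position but not the reason.

The entering group brings a chlorine, a methyl and a five-membered aromatic ring with a sulfur in one change, and the compounds shown do not tell which of these parts carries the step. Also open, as far as these compounds go, is how the number in this assay would respond to a thiazole with an amine in place of the chlorine, or to a thiazole with no methyl.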